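Tetrazole series: chloro in place of fluoro on the aryl ring

A few compounds are considered here, and "the series" means these few. Any claim that something is new, unique, unknown or untested is made for them only; others in the source may bear on it.

Of the compounds shown here, three sharing a common core have been tested in a functional assay on C6 cells (Rattus norvegicus) for cytotoxicity, read by MTT assay, with a stated time of 24 h, tested at 200 ug/mL; on this read-out higher numbers stand for a weaker effect at the one concentration tested and lower numbers for a stronger effect. Compound 1 `Cc1nnc(SCC(=O)N/N=c2/scc(-c3ccc(Cl)cc3)n2-c2ccccc2)s1` gives 29%. Compound 2 `Cc1ccc(-c2cs/c(=N/NC(=O)CSc3nnnn3-c3ccccc3)n2-c2ccccc2)cc1` gives 22.2%. Compound 3 `O=C(CSc1nnnn1-c1ccccc1)N/N=c1/scc(-c2ccc(F)cc2)n1-c1ccccc1` gives 30.6%, the highest of the three numbers, though its gaps to compound 1 and to compound 2 both lie within the scatter, so no order among them can be claimed. Going by the values given here, the one single-point step measured so far is a number 8.4 percentage points higher from compound 2 to compound 3 (within the scatter).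

Compound 4 `O=C(CSc1nnnn1-c1ccccc1)N/N=c1/scc(-c2ccc(Cl)cc2)n1-c1ccccc1` differs from compound 3 as follows: chloro in place of fluoro on an aromatic carbon. Among the compounds with values here, no measured step bears directly on this exchange; compound 1 also carries a chloro group on the same phenyl, but its core differs from that of compound 4 in a second place, so only its value and that of compound 3 can be set side by side, and they agree within the scatter. Compound 4 is therefore expected to read close to compound 3, with an expected step of a number 1.6 percentage points lower from compound 3 to compound 4 (within the scatter) that stays within the scatter. The estimate for compound 4 is 29%, with a range from 18% to 40%.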

Compound 4, a percentage reported as activity, at one concentration (the size of the read-out at that concentration, not a potency): 52.4%
Compound 4: the middle estimate sits 23.4 percentage points below what was measured; the measured number lies above the stated range.
By their numbers in this assay, from the lowest: compounds 2, 1 and 3 (each within the scatter of the next); then compound 4.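

In this assay, going by these compounds alone, this is the first change on the aromatic carbon para to a large group that moves the number beyond the scatter: chloro in place of fluoro gives a number 21.8 percentage points higher from compound 3 to compound 4 (beyond the scatter) and chloro in place of methyl gives a number 30.2 percentage points higher from compound 2 to compound 4 (beyond the scatter), so chloro stands apart from both with a weaker effect at the one concentration tested. The 4-chlorophenyl group does not set the number alone, since 1-phenyl-1H-tetrazol-5-yl in place of 5-methyl-1,3,4-thiadiazol-2-yl on the sulfur gives a number 23.4 percentage points higher from compound 1 to compound 4 (beyond the scatter) with that aryl group unchanged. Nothing available explains either shift.

The compounds shown leave open whether bromo, methoxy or a plain hydrogen at this position would read with chloro or with fluoro and methyl. They also leave open whether chloro in place of fluoro would give a similar step with 5-methyl-1,3,4-thiadiazol-2-yl on the sulfur.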